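The compounds below may be only part of what the source reports. "The series", "measured", "known", "first", "only" and "open" are said of these compounds alone.

In a functional assay on SK-MEL cells (Homo sapiens) for cytotoxicity, read by MTT assay, with a stated time of 6 days (on this read-out higher numbers stand for an effect only at larger amounts of compound and lower numbers for an effect already at smaller amounts), compound 1 (`COC(=O)c1c(-c2cc(OC)cc(OC)c2)oc2ccccc2c1=O`) gives > 25 ug/mL, a limit of the assay and not a number. Compound 2 (`COc1cc(-c2oc3ccccc3c(=O)c2C(=O)O)cc(OC)c1OC`) gives > 25 ug/mL, which is also only a limit, so it stands with compound 1 at the limit of > 25 ug/mL in this assay, at which 2 of the 2 values shown sit. Compound 3 (`COc1cc(OC)cc(-c2oc3ccccc3c(=O)c2C(=O)O)c1`) has hydrogen in place of methoxy on an aromatic carbon, para to a large group: hydrogen in place of methoxy on an aromatic carbon. With only this limit to go on, no change beyond the usual scatter is expected in this assay. The estimated step of a number no higher from compound 2 to compound 3 (the limit leaves the size open) is expected to stay within that scatter. For compound 3 the expected value is 25 ug/mL, estimated to lie between 12 ug/mL and 50 ug/mL.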

Compound 3, concentration for half-maximal effect: > 25 ug/mL
Compound 3: a limit, no number; the forecaster's own chance of this, stated with the estimate: 85%; the middle value sits exactly at the limit.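

Compound 3 also gives only a limit, so the steps to it from compound 1 and from compound 2 cannot be read: the limit of > 25 ug/mL in this assay, at which 3 of the 3 values shown sit. The compounds shown leave open whether any of these changes shifts the effect in this assay.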